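Swapping the aryl ring on a four-membered lactam core

This account rests on a few compounds, and the source may have more. Where it says the series, first, only, none or still open, it means among the compounds named here.

Compound 1 `COc1cc(N2C(=O)C(O)C2c2ccc(SC)cc2)cc(OC)c1OC` is a small lactam carrying a hydroxy group on the saturated ring and a 4-(methylsulfanyl)phenyl group on the neighbouring ring carbon. In a functional assay on MCF7 cells (Homo sapiens) for inhibition, read by resazurin assay, with a stated time of 72 h (a higher number here means a weaker inhibitor, a lower number a stronger inhibitor), compound 1 gives 5 nM, the lowest number of the three measured compounds. Compound 3 `C=CC1C(=O)N(c2cc(OC)c(OC)c(OC)c2)C1c1ccc(SC)cc1` gives 51 nM, and the single-point change a 10-fold higher number from compound 1 to compound 3 (1.01 log units; beyond the scatter) is large. Compound 2 `CCOc1ccc(C2CC(=O)N2c2cc(OC)c(OC)c(OC)c2)cc1` gives 64 nM, but it differs from compound 1 in more than one place, so only the two values themselves can be compared.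

Compound 4 `COc1ccc(C2C(O)C(=O)N2c2cc(OC)c(OC)c(OC)c2)cc1O` keeps the hydroxy group and the shared core of compound 1 and differs only in the aryl group: 3-hydroxy-4-methoxyphenyl in place of 4-(methylsulfanyl)phenyl on a saturated ring carbon. Within the data shown here, no measured step changes this group alone, so nothing measured bears directly on the move. With the hydroxy-bearing core retained, compound 4 is expected to remain a strong inhibitor, and the step of no change at the digits printed from compound 1 to compound 4 (within the scatter) is expected to stay within the scatter. Compound 4 is therefore estimated at 5 nM, with a range from 1 nM to 25 nM.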

Compound 4, half-maximal inhibitory concentration: 3 nM
Compound 4: middle estimate off by 1.7-fold (0.22 log units), on the high side, within the range that was stated.
By their numbers in this assay, from the lowest: compounds 4 and 1 (each within the scatter of the next); then compounds 3 and 2 (each within the scatter of the next).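

Among these compounds, until now the only single-place step touched the hydroxy group on the ring, whereas this one changes the aryl group on a saturated ring carbon and gives a 1.7-fold lower number from compound 1 to compound 4 (0.22 log units; within the scatter) in this assay. The sulfur-containing 4-(methylsulfanyl)phenyl, with 0 hydrogen-bond donors, can therefore give way to 3-hydroxy-4-methoxyphenyl, with 1 hydrogen-bond donor, and the compound remains a strong inhibitor. Nothing available explains why these two aryl groups give values so close together.

As far as these compounds go, the hydroxy and methoxy groups enter together, so what each contributes on its own remains open. Also unsettled are whether an amine or a carboxylic acid on this aryl ring would be accepted, and whether vinyl in place of the ring hydroxy would raise the number as much with the new aryl group.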